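A few compounds are considered here, and "the series" means these few. Any claim that something is new, unique, unknown or untested is made for them only; others in the source may bear on it.

Compound 1 `Cc1ccc(O)c(C(O)(C(F)(F)F)C(F)(F)F)c1` gives 454000 nM in an assay on isolated protein for inhibition of tyrosine-protein phosphatase non-receptor type 13 (Homo sapiens), read by spectrophotometry; a lower number here means a stronger inhibitor, a higher number a weaker inhibitor. Compound 2 `Oc1cc(-c2ccccc2)ccc1C(O)(C(F)(F)F)C(F)(F)F` is a different case: in this assay compound 2 gives > 500000 nM, which is a limit of the assay rather than a number (the limit of > 500000 nM in this assay, at which 1 of the 3 values shown sits). Compound 3 `CCN(CC)C(=O)COc1ccc2cc(C(O)(C(F)(F)F)C(F)(F)F)c(O)cc2c1` also stops at a boundary: in this assay compound 3 gives > 20000 nM, again a limit and not a number (the limit of > 20000 nM in this assay, at which 1 of the 3 values shown sits). So compound 3 stands at a limit, one of two limits among the three values shown, and no number places it above or below compound 1.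

Compound 4 `O=C(COc1ccc2cc(C(O)(C(F)(F)F)C(F)(F)F)c(O)cc2c1)Nc1nc2ccccc2s1` differs from compound 3 by (1,3-benzothiazol-2-yl)amino in place of diethylamino on a carbonyl carbon. Among the compounds with values here, no step between two measured compounds is given here, so the size of this change can only be guessed, and with compound 3 at a limit a move beyond the scatter in either direction cannot be ruled out. Compound 4 is expected to give about 20000 nM in this assay, with a range from 5000 nM to 80000 nM. That estimate means an expected step of a number no higher from compound 3 to compound 4 (the limit leaves the size open), while a fair chance remains that only a limit is reported.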

Compound 4, half-maximal inhibitory concentration: 9900 nM
Beside the measured number, compound 4's estimate is 2.0-fold (0.31 log units) above it; the range from low to high includes it.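

Compound 3 stands only at a limit of the assay: the limit of > 20000 nM in this assay, at which 1 of the 4 values shown sits.

Placing (1,3-benzothiazol-2-yl)amino in place of diethylamino on a carbonyl carbon gives an at least 2.0-fold lower number from compound 3 to compound 4 (0.30 log units; that floor lies within the scatter), so the real size of the step stays unknown and only its floor can be read. What is new is that this place accepts a group with two aromatic rings and that the series now has a measured number: in this assay compound 4 gives 9900 nM.

The compounds shown leave open whether the two aromatic rings or the amide hydrogen matter more for that number. A phenylamino or a methylamino group on the same carbonyl carbon would help to separate the two, and a carboxylic acid there would test whether the amide is needed at all.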